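Adding a methoxy group to a quinoxaline dioxide core

The source may report more compounds than this note shows. Statements on the series, on what has been measured and on what is new or still open speak of the compounds shown alone.

Of the compounds shown here, two sharing one core have been measured in a functional assay on PC-3 cells (Homo sapiens) for cytotoxicity, read by MTT assay, with a stated time of 72 h; on this read-out higher numbers stand for weaker inhibition and lower numbers for stronger inhibition. Compound 1 `COc1ccc2c(c1)[n+]([O-])nc(NCOC(C)c1ccccc1)[n+]2[O-]` gives 4140 nM. Compound 2 `CCCCCOCNc1n[n+]([O-])c2ccccc2[n+]1[O-]` gives 9200 nM, the highest of the two numbers; the gap to compound 1 lies beyond the usual scatter, though the two compounds differ in more than one place. Compound 3 `CCCCCOCNc1n[n+]([O-])c2cc(OC)ccc2[n+]1[O-]` is compound 2 with methoxy in place of hydrogen on an aromatic carbon. Compound 1 also carries that methoxy group and gives the lower number, so a small step downward is expected, possibly within scatter; compound 3 is estimated at 6000 nM, between 2500 nM and 15000 nM, a step of a 1.5-fold lower number from compound 2 to compound 3 (0.19 log units; within the scatter).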

Compound 3, half-maximal inhibitory concentration: 3630 nM
For compound 3 the middle estimate is 1.7-fold (0.22 log units) above the measured one; the measured number falls inside the stated range.
By their numbers in this assay, from the lowest: compounds 3 and 1 (each within the scatter of the next); then compound 2.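

Methoxy in place of hydrogen on an aromatic carbon of the shared core gives a 2.5-fold lower number from compound 2 to compound 3 (0.40 log units; beyond the scatter) as a clean single-place change, something the earlier pair could not show. With that methoxy present, pentyl in place of 1-phenylethyl on the oxygen gives a 1.1-fold lower number from compound 1 to compound 3 (0.06 log units; within the scatter) and so does not separate the two chains. No measurement here explains the methoxy step. As far as these compounds go, whether a fluorine or an amine on the same aromatic carbon would act like methoxy remains open. So does the effect of a longer chain in place of pentyl.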